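The source may report more compounds than this note shows. Statements on the series, on what has been measured and on what is new or still open speak of the compounds shown alone.

Measured compounds:
Compound 1, `O=C(O)CC(CC(=O)NNC(=O)CCCCNc1ccccn1)c1ccc(F)cc1`: 2.23
Compound 2, `O=C(O)CC(NC(=O)NNC(=O)CCCCNc1ccccn1)c1ccccc1`: 1.64

In a physicochemical assay for lipophilicity (on this read-out higher numbers stand for higher lipophilicity and lower numbers for lower lipophilicity), compound 1 gives 2.23. Compound 2 gives 1.64 in this assay, the lower of the two numbers; the gap to compound 1 lies beyond the usual scatter of repeated measurements, so compound 2 stands clearly below compound 1. The two compounds differ in more than one place, so no single step can be read from them.

Compound 3, `O=C(O)CC(NC(=O)NNC(=O)CCCCNc1ccccn1)c1cccc2ccccc12`, has not yet been measured. It differs from compound 2 in one place: naphthalen-1-yl in place of phenyl on a saturated chain carbon bound to an amide-type nitrogen and a saturated chain carbon. The entering group carries the larger count of ring carbons, and the two rings replace one. Among the measured compounds shown here, no step of this kind is known among the measured compounds, so the expectation rests on the structural change alone. Adding a second aromatic ring in this way is expected to raise the partition coefficient well beyond the scatter, and the expected step is a number 1.16 log units higher from compound 2 to compound 3 (beyond the scatter). Compound 3 is therefore estimated at 2.8, with a range from 2.3 to 3.3.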

Compound 3, partition coefficient: 2.64
The estimate for compound 3 lay 0.16 log units above the measured number; low and high end bracket the measured number.
By their numbers in this assay, from the lowest: compound 2; then compound 1; then compound 3.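

Among the compounds shown here, compound 2 and compound 3 form the first pair here that differs in one place only, so a change at this position can now be read on its own. In this assay, naphthalen-1-yl in place of phenyl on a saturated chain carbon bound to an amide-type nitrogen and a saturated chain carbon gives a number 1.00 log units higher from compound 2 to compound 3 (beyond the scatter), a clear move on this read-out when two aromatic rings of carbon stand where one stood, with neither group carrying hydrogen-bond donors, hydrogen-bond acceptors or a net charge. Nothing available here explains the size of this step.

The compounds shown leave open whether a step of this size holds for other groups on the same carbon, as a single pair gives no trend. A cyclohexyl group, a pyridine ring, or a phenyl ring carrying an amine or a carboxylic acid could show whether the number follows the count of rings, the count of ring carbons, or something else.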